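A few compounds are considered here, and "the series" means these few. Any claim that something is new, unique, unknown or untested is made for them only; others in the source may bear on it.

Compound 1: `Cn1ncnc1-c1cc(Oc2ccc(NC(=O)Nc3cccc(C(F)(F)F)c3)cc2F)ccn1` — > 50000 nM
Compound 2: `CN(C)CCn1cnnc1-c1cc(Oc2ccc(NC(=O)Nc3ccccc3C(F)(F)F)cc2F)ccn1` — 5860 nM
Compound 3: `CCN(CC)CCn1cnnc1-c1cc(Oc2ccc(NC(=O)Nc3ccc(F)c(F)c3)cc2F)ccn1` — 1240 nM

All three were tested in a functional assay on HT-29 cells (Homo sapiens) for antiproliferative activity, read by MTT assay, with a stated time of 72 h; a higher number here means a weaker inhibitor, a lower number a stronger inhibitor. Compound 1 stands at the limit of > 50000 nM in this assay, at which 1 of the 3 values shown sits, so for compound 1 only a limit is known, not a number. Compound 2 gives 5860 nM in this assay, and compound 3 gives 1240 nM. Among the compounds with values here, no pair among the three differs in a single place, so no measured step can be set out, but both compounds 2 and 3 return measurable numbers where compound 1 does not.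

Compound 4, `CN(C)CCCn1cnnc1-c1cc(Oc2ccc(NC(=O)Nc3cccc(C(F)(F)F)c3)cc2F)ccn1`, is the unmeasured one. It differs from compound 1 in one place: 4-(3-(dimethylamino)propyl)-4H-1,2,4-triazol-3-yl in place of 1-methyl-1H-1,2,4-triazol-5-yl on an aromatic carbon. Compounds 2 and 3 also carry a longer chain on the triazole rather than the methyl of compound 1, though they differ from compound 1 elsewhere as well, so their values only hint at what this change may bring. On that basis the step from compound 1 to compound 4 is expected to be a gain in potency beyond the usual scatter, with an at least 12-fold lower number from compound 1 to compound 4 (1.09 log units; beyond the scatter) as the estimated size. Compound 4 is expected to give about 4000 nM in this assay, most likely between 1000 nM and 20000 nM.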

Compound 4, half-maximal inhibitory concentration: 980 nM
The estimate for compound 4 lay 4.1-fold (0.61 log units) above the measured number; measured number below the stated range.
By their numbers in this assay, from the lowest: compounds 4 and 3 (each within the scatter of the next); then compound 2. At a limit, above all of these: compound 1.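

Only one place differs between these two molecules, so the swap of 1-methyl-1H-1,2,4-triazol-5-yl for 4-(3-(dimethylamino)propyl)-4H-1,2,4-triazol-3-yl, on the aromatic carbon next to the ring nitrogen, can be read on its own in this assay: it gives an at least 51-fold lower number from compound 1 to compound 4 (1.70 log units; beyond the scatter). Compounds 2 and 3 could only hint at this, since each also differs from compound 1 elsewhere, whereas this step shows that the change at this position alone is enough to bring a large gain in antiproliferative potency. Compound 1 sits at a limit rather than at a number, so the step gives only the smallest possible size of the gain, and the true size stays unknown: the limit of > 50000 nM in this assay, at which 1 of the 4 values shown sits.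

The change also combines two things, a different arrangement of the triazole and the added aminoalkyl chain, and the compounds shown cannot separate them. A 4-methyl-4H-1,2,4-triazol-3-yl group would isolate the ring arrangement, while a plain propyl chain with no amine, or a chain ending in a morpholine or a carboxylic acid, would test how much the dimethylamino end contributes.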